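Amide series: methyl to ethyl at the aryl position

The source may hold more compounds than are shown below. What is called first, only, known or untested is meant among the compounds shown, and "the series" means these compounds.

Measured so far:
compound 1 `COc1cc(C(=O)Nc2nn[nH]n2)nc(-c2ccccc2)c1` — 97%
compound 2 `Cc1cc(C(=O)Nc2nn[nH]n2)nc(-c2ccccc2)c1` — 50%

In a functional assay on the whole organism with Rattus norvegicus as the target, at a dose of 3 mg/kg by the oral route (a higher number here means a stronger effect of the compound at the dose given, a lower number a weaker effect), compound 1 gives 97%. Among the measured compounds shown here, compound 2 gives 50% in this assay, the lowest of the two numbers; its nearest neighbour is compound 1, and the only measured step is a number 47 percentage points lower from compound 1 to compound 2 (beyond the scatter), methyl in place of methoxy on an aromatic carbon.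

Compound 3 `CCc1cc(C(=O)Nc2nn[nH]n2)nc(-c2ccccc2)c1` differs from compound 2 by methyl in place of hydrogen on a saturated chain carbon bound to an aromatic carbon. For the measured compounds named here, no measured pair shows this change: the one step, a number 47 percentage points lower from compound 1 to compound 2 (beyond the scatter), concerns an exchange of methoxy for methyl and does not bear on a methyl-to-ethyl extension. Going by the values given here, with nothing to go on beyond the one number for compound 2, no step beyond the scatter is expected in this assay in either direction, and the range must be wide. Compound 3 is expected at 45%, within 15% to 80%. The expected step is a number 5 percentage points lower from compound 2 to compound 3 (within the scatter).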

Compound 3, a percentage reported as inhibition, in the whole organism at one dose (the size of the read-out at that dose, not a potency): 53%
Compound 3: the middle estimate sits 8 percentage points below what was measured; measured number inside the range.
By their numbers in this assay, from the lowest: compounds 2 and 3 (each within the scatter of the next); then compound 1.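

In this assay, methyl in place of hydrogen on a saturated chain carbon bound to an aromatic carbon gives a number 3 percentage points higher from compound 2 to compound 3 (within the scatter) and so does not separate ethyl from methyl at this position. Ethyl in place of methoxy on the same aromatic carbon gives a number 44 percentage points lower from compound 1 to compound 3 (beyond the scatter), so a second group joined through carbon also stands well short of the methoxy compound. No measured evidence bears on the gap between methoxy and these two alkyl groups.

Going by these compounds, whether an ethoxy group, a hydroxyl, an amine or a longer chain on this aromatic carbon would stay with the methyl and ethyl pair or approach compound 1 remains open. With one oral dose shown, it also remains open whether the gap holds at other doses.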